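Series notes: methoxy addition to the core of compound 1

The compounds below may be only part of what the source reports. "The series", "measured", "known", "first", "only" and "open" are said of these compounds alone.

Measured so far:
compound 1 — `COc1ccc(-c2[nH]c3ccccc3c2/C=C(\C#N)S(=O)(=O)c2ccccc2)cc1` — in a functional assay on UACC-62 cells (Homo sapiens) for inhibition, read by sulforhodamine B assay, with a stated time of 48 h (on this read-out lower numbers stand for stronger inhibition of growth and higher numbers for weaker inhibition of growth), compound 1 gives 597 nM
compound 2 — `CCOC(=O)C(=Cc1c(-c2ccccc2)[nH]c2ccccc12)C(=O)OCC` — in this assay compound 2 gives 4600 nM

Among the measured compounds shown here, compound 1 has the lowest of the two numbers measured in this assay so far. Compound 2, which carries a different core and a different substituent pattern on the two-carbon arm, gives the higher number, and the gap between compound 1 and compound 2 lies beyond the usual scatter. For the measured compounds named here, no pair of measured compounds differs in one place only, so no single-change step in this assay is available within this set.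

The unmeasured compound 3, `COc1ccc(-c2[nH]c3ccc(OC)cc3c2/C=C(\C#N)S(=O)(=O)c2ccccc2)cc1`, differs from compound 1 in one place: methoxy in place of hydrogen on an aromatic carbon. The rest of compound 1 — the two-carbon arm with its nitrile and phenylsulfonyl groups, and the methoxyphenyl attached to the core — is kept.

Nothing measured here speaks to what a methoxy at this place on the core does in this assay. The expectation for compound 3 is therefore a step from compound 1 of a 1.3-fold lower number from compound 1 to compound 3 (0.12 log units; within the scatter), that is, no change beyond the scatter, with a slight lean toward a lower number. Compound 3 is estimated at 450 nM, expected within a range of 150 nM to 1500 nM.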

Compound 3, concentration for 50% growth inhibition: 660 nM
Beside the measured number, compound 3's estimate is 1.5-fold (0.17 log units) below it; the range from low to high includes it.
By their numbers in this assay, from the lowest: compounds 1 and 3 (each within the scatter of the next); then compound 2.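

In this assay, methoxy in place of hydrogen on an aromatic carbon of the core, at the place meta to a fused ring and para to a fused ring, gives a 1.1-fold higher number from compound 1 to compound 3 (0.04 log units; within the scatter). Among the compounds shown here, this is the first single-change step available, and it shows that, with the two-carbon arm bearing the nitrile and phenylsulfonyl groups and the methoxyphenyl kept, adding methoxy at this place leaves the read-out within the scatter, so compound 1 and compound 3 cannot be told apart here. No measurement at hand offers an explanation for this outcome.

The series leaves open whether this place accepts groups other than methoxy just as well, such as a hydroxyl, an amine, a carboxylic acid or a longer chain like butoxy, since a single group at a single place gives no trend. It also leaves open whether methoxy on the other aromatic carbons of the same ring would give a similar result, and whether a second group on the core would add anything to this one.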